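Swapping Methoxy for Methyl on an Aromatic Ring

The compounds below may be only part of what the source reports. "The series", "measured", "known", "first", "only" and "open" are said of these compounds alone.

In a functional assay on NB1 cells (Homo sapiens) for antiproliferative activity, with a stated time of 72 h (a higher number here means a weaker inhibitor, a lower number a stronger inhibitor), three compounds sharing one core have been measured: compound 1 `COc1cc(OC)cc(C(=O)N(CCC(=O)NCc2ccccc2)Cc2ccc(C(=O)NO)cc2)c1` gives 13300 nM, compound 2 `CN(C)c1ccc(C(=O)N(CCC(=O)NCc2ccccc2)Cc2ccc(C(=O)NO)cc2)cc1` gives 1720 nM, and compound 3 `COc1ccc(C(=O)N(CCC(=O)NCc2ccccc2)Cc2ccc(C(=O)NO)cc2)cc1` gives 2520 nM. Compound 3 cannot be told apart from compound 2, yet its number is clearly lower than that of compound 1. The next compound, compound 4 `Cc1ccc(C(=O)N(CCC(=O)NCc2ccccc2)Cc2ccc(C(=O)NO)cc2)cc1`, carries methyl in place of methoxy on an aromatic carbon, para to a large group: methyl in place of methoxy on an aromatic carbon. The nearest guide is the earlier exchange at that same place, a 1.5-fold higher number from compound 2 to compound 3 (0.17 log units; within the scatter), which stayed within the scatter. The steps of a 7.7-fold lower number from compound 1 to compound 2 (0.89 log units; beyond the scatter) and a 5.3-fold lower number from compound 1 to compound 3 (0.72 log units; beyond the scatter) were larger, but each exchanged a whole ring group on a carbonyl carbon, not a single group on the ring. No step beyond the scatter is therefore expected in this assay. The estimated change is a 1.0-fold lower number from compound 3 to compound 4 (0.00 log units; within the scatter). For compound 4 the expected value is 2500 nM, with an estimated range of 1200 nM to 5500 nM.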

Compound 4, half-maximal inhibitory concentration: 1610 nM
Compound 4: the middle estimate sits 1.6-fold (0.19 log units) above what was measured; the range from low to high includes it.
By their numbers in this assay, from the lowest: compounds 4, 2 and 3 (each within the scatter of the next); then compound 1.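

In this assay methyl on this aromatic carbon, with no oxygen and no hydrogen-bond acceptor, reads as a 1.6-fold lower number from compound 3 to compound 4 (0.19 log units; within the scatter) and as a 1.1-fold lower number from compound 2 to compound 4 (0.03 log units; within the scatter) and so methoxy, dimethylamino and methyl cannot be told apart here, a picture that now rests on three groups instead of two. The exchange of the whole ring group, read as an 8.3-fold lower number from compound 1 to compound 4 (0.92 log units; beyond the scatter) and lying beyond the scatter, leaves compound 1 with its 3,5-dimethoxyphenyl apart from all three compounds that carry one group on the ring. No measurement shown here explains this pattern.

Still open, from the compounds shown here alone, is whether a carboxylic acid or a longer chain such as butyl on this aromatic carbon would also stay within the scatter. A hydroxyl group or a chlorine atom there remains equally untested among the compounds shown.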